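Piperidinyl-piperidine sulfonamides: a fluorobenzyl extension of compound 2

This account rests on a few compounds, and the source may have more. Where it says the series, first, only, none or still open, it means among the compounds named here.

Compound 1 `Cc1cc(C)c(S(=O)(=O)N2CCC(C(=O)N3CCC(C)CC3)CC2)c(C)c1`: > 5000 nM
Compound 2 `Cc1cc(C)c(S(=O)(=O)N2CCC(N3CCC(C)CC3)CC2)c(C)c1`: 0.03 nM
Compound 3 `Cc1cc(C)c(S(=O)(=O)N2CCC(N3CCC(C)OC3)CC2)c(C)c1`: 92 nM

Three compounds share a core and were tested in a functional assay on DLD-1 cells (Homo sapiens) for antiproliferative activity, read by CellTiter-Glo, with a stated time of 72 h; on this read-out lower numbers stand for stronger inhibition and higher numbers for weaker inhibition. Compound 1 reaches only the assay limit, > 5000 nM, which is a limit rather than a number (the limit of > 5000 nM in this assay, at which 1 of the 3 values shown sits). Compound 2 gives the lowest number of the two numbers shown, 0.03 nM, and its nearest neighbour is compound 3 at 92 nM, reached through a 3100-fold higher number from compound 2 to compound 3 (3.49 log units; beyond the scatter). The step from compound 1 also points the same way, an at least 160000-fold lower number from compound 1 to compound 2 (5.22 log units; beyond the scatter).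

Compound 4 `Cc1cc(C)c(S(=O)(=O)N2CCC(N3CCC(Cc4ccccc4F)CC3)CC2)c(C)c1` differs from compound 2 by 2-fluorophenyl in place of hydrogen on a saturated chain carbon bound to a saturated ring carbon. Going by the values given here, none of the measured steps touches this position: they change the linking group or the ring that carries the methyl, not the methyl itself. Among the compounds with values here, compound 2 therefore gives the anchor, and the expectation for compound 4 rests on a change for which the set holds no direct precedent. Compound 4 is expected to give about 1 nM in this assay, within 0.05 nM to 20 nM. That estimate means the step of a 33-fold higher number from compound 2 to compound 4 (1.52 log units; beyond the scatter), a loss that is expected but uncertain given the extreme number of compound 2.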

Compound 4, half-maximal inhibitory concentration: 74 nM
Compound 4: the middle estimate sits 74-fold (1.87 log units) below what was measured; measured number above the stated range.
By their numbers in this assay, from the lowest: compound 2; then compounds 4 and 3 (each within the scatter of the next). At a limit, above all of these: compound 1.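

Replacing methyl with 2-fluorobenzyl, the only change at this position among the compounds shown, gives a 2500-fold higher number from compound 2 to compound 4 (3.39 log units; beyond the scatter) in this assay and thus adds a direct measure for a place the earlier steps left untouched. The position does not take the added 2-fluorophenyl without a large loss, yet inhibition is not abolished, since compound 4 gives 74 nM in this read-out. Nothing measured here bears on why the step is so large.

On these data alone, whether the loss follows the phenyl ring or the fluorine stays open, and a plain benzyl, an ethyl or a longer chain on this carbon would separate the two. As far as these compounds go, it is equally open how an amine or a carboxylic acid on the same carbon would compare with methyl.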